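The compounds below may be only part of what the source reports. "The series", "measured", "known", "first", "only" and "open" are said of these compounds alone.

Compound 1 `CCN(CC)CCCCOc1c(OCc2ccccc2)cc2oc(-c3ccccc3)cc(=O)c2c1O` and compound 2 `COc1cc2oc(-c3ccccc3)cc(=O)c2c(O)c1OCCCN1CCN(C)CC1` share a core and were both tested in a functional assay on BCG823 cells (Homo sapiens) for antiproliferative activity, read by MTT assay, with a stated time of 48 h; a lower number here means a stronger inhibitor, a higher number a weaker inhibitor. In this assay compound 1 gives 4200 nM, while compound 2 gives 31300 nM. Compound 2 therefore has the highest number of the two, and the gap between compound 2 and compound 1 lies beyond the usual scatter of repeated measurements. Compound 3 `COc1cc2oc(-c3ccccc3)cc(=O)c2c(O)c1OCCCCN1CCCC1` has not yet been measured. It differs from compound 2 in one place: (pyrrolidin-1-yl)methyl in place of 4-methylpiperazin-1-yl on a saturated chain carbon, three bonds along the chain from an oxygen on an aromatic ring. Among the measured compounds shown here, no measured pair shows this exact change, so its effect cannot be read directly from the numbers. The step from compound 2 to compound 3 is estimated as a 2.1-fold lower number from compound 2 to compound 3 (0.32 log units; beyond the scatter), expected to point toward a lower number, though it might stay within the scatter. Compound 3 is expected to give 15000 nM in this assay, with a likely range from 5000 nM to 45000 nM.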

Compound 3, half-maximal inhibitory concentration: 10600 nM
Compound 3: the middle estimate sits 1.4-fold (0.15 log units) above what was measured; low and high end bracket the measured number.
By their numbers in this assay, from the lowest: compound 1; then compound 3; then compound 2.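

Read as 3-(4-methylpiperazin-1-yl)propyl giving way to 4-(pyrrolidin-1-yl)butyl, the change in this assay gives a 3.0-fold lower number from compound 2 to compound 3 (0.47 log units; beyond the scatter). Among the compounds shown here, this is the first direct reading at this position, and it shows that the group carried on the saturated chain carbon can alter the antiproliferative number by a modest step. The step combines a different ring with a longer chain, so it cannot be assigned to either one alone, and no measurement at hand gives a reason for it.

A 3-(pyrrolidin-1-yl)propyl group on the same core would separate the ring from the chain length. On these data alone, it also remains open how a morpholine or piperidine ring, or an open diethylamine on the butyl chain, would compare with the pyrrolidine of compound 3.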